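The compounds below may be only part of what the source reports. "The series", "measured", "known", "first", "only" and "open" are said of these compounds alone.

Working notes on the series. Among the measured compounds shown here, in a physicochemical assay for lipophilicity, in phosphate buffer, measured as octanol-water partition, with a stated time of 24 h (a lower number here means a more polar compound, a higher number a more lipophilic compound), compound 3 `Cc1cc(Oc2ccc(/C=N/NC(=S)Nc3ccc(Br)cc3)cc2)ccc1Cl` stands highest of the three numbers measured so far: compound 3 gives 7.89. Nearest to it is compound 2 `S=C(N/N=C/c1ccc(Oc2ccc(Br)cc2)cc1)Nc1ccc(Cl)cc1`, which in this assay gives 6.37; furthest is compound 1 `Cc1ccc(Oc2ccc(/C=N/NC(=S)Nc3ccc(Cl)cc3)cc2)cc1`, which in this assay gives 5.97. Compound 2 and compound 3 differ in more than one place, so only their two numbers are set side by side here. Compound 1 and compound 2 differ in one place, and that step reads a number 0.40 log units higher from compound 1 to compound 2 (beyond the scatter).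

Compound 4 `Cc1cc(Oc2ccc(/C=N/NC(=S)Nc3ccc(Cl)cc3)cc2)ccc1Cl` is the next one to be measured in this assay. It differs from compound 3 in one place: chloro in place of bromo on an aromatic carbon. For the measured compounds named here, no measured step exchanges bromo for chloro. Going by the values given here, the only measured step, a number 0.40 log units higher from compound 1 to compound 2 (beyond the scatter), bears on it at most indirectly, since it puts bromo in place of methyl rather than chloro in place of bromo, and it is modest in size. The exchange of one of these two groups for the other is therefore expected to give, at most, a small step in this assay, if anything downward, and possibly none beyond the scatter. The expected step is a number 0.24 log units lower from compound 3 to compound 4 (within the scatter). For compound 4 the estimated value in this assay is 7.65, with a range from 7.2 to 8.1.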

Compound 4, partition coefficient: 6.59
Compound 4: the middle estimate sits 1.06 log units above what was measured; the whole stated range lies above it.
By their numbers in this assay, from the lowest: compound 1; then compounds 2 and 4 (each within the scatter of the next); then compound 3.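

In this assay, among the compounds shown here, the position on the 4-bromophenyl of the (4-bromophenyl)amino group now has a measured halogen exchange, and going to 4-chlorophenyl reads (a number 1.30 log units lower from compound 3 to compound 4 (beyond the scatter)), a large step from a change of one halogen for another and well above the only earlier step, which was modest. The aryl group on the oxygen gives two further readings: 4-chloro-3-methylphenyl in place of 4-bromophenyl reads (a number 0.22 log units higher from compound 2 to compound 4 (within the scatter)), and the same group in place of 4-methylphenyl reads (a number 0.62 log units higher from compound 1 to compound 4 (beyond the scatter)), so the largest step shown so far belongs to the halogen on the amino side, not to the group on the oxygen. Nothing available accounts for the size of the bromo to chloro step, and the data shown give no reason for it.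

As far as these compounds go, the exchange rests on a single pair, so whether a step of this size recurs with 4-methylphenyl or 4-bromophenyl on the oxygen stays open. How a fluoro, a methoxy or an amine at the same place would read against bromo and chloro is also open, as the compounds shown carry only these two halogens there.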